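The source may hold more compounds than are shown below. What is called first, only, known or untested is meant among the compounds shown, and "the series" means these compounds.

Measured in a functional assay on SNU-638 cells (Homo sapiens) for cytotoxicity, read by MTT assay; on this read-out higher numbers stand for weaker inhibition and lower numbers for stronger inhibition:

- compound 1 `COc1ccc(C(=O)/C=C/c2ccc(F)cc2)c(O)c1`: 18400 nM
- compound 2 `O=C(/C=C/c1ccc(N2CCCC2)cc1)c1ccc(O)cc1`: 620 nM
- compound 3 `O=C(/C=C/c1ccc(N2CCCC2)cc1)c1ccc(F)cc1`: > 25000 nM, a limit and not a number

Of compound 3 only a limit is known, and the data record it as the limit of > 25000 nM in this assay, at which 1 of the 3 values shown sits. Compound 4 `O=C(/C=C/c1ccc(N2CCCC2)cc1)c1ccc([N+](=O)[O-])cc1` carries nitro in place of fluoro on an aromatic carbon, para to a large group: nitro in place of fluoro on an aromatic carbon. Going by the values given here, no measured step makes this exchange directly. The nearest evidence is an at least 40-fold higher number from compound 2 to compound 3 (1.60 log units; beyond the scatter), a large step beyond the scatter, with fluoro in place of hydroxy on an aromatic carbon. Compound 4 also lacks the hydroxy of compound 2, which gives 620 nM. Among the compounds with values here, compound 1 differs from the others in more than one place, so it supplies no step here. On this basis, no return towards compound 2 is expected, and compound 4 may also be reported only as a limit. The expected change is an at least 1.2-fold lower number from compound 3 to compound 4 (0.09 log units; that floor lies within the scatter), estimated to stay within the scatter, with its direction left open. For compound 4 the estimated value is 20000 nM, with an expected range from 4000 nM to 60000 nM.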

Compound 4, half-maximal inhibitory concentration: > 25000 nM
Compound 4 was reported as a limit; the forecaster's own chance of this, stated with the estimate: 50%; middle value at least 1.2-fold (0.09 log units) away from the limit.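

In this assay, a second replacement of the hydroxy of compound 2 ends in the same place as the first, with an at least 40-fold higher number from compound 2 to compound 4 (1.60 log units; beyond the scatter), this time with a nitro group taking the place of that hydroxy. Compound 3 and compound 4 are both known only as limits, so the step between them cannot be read, and the data do not separate fluoro from nitro at this place. Two different groups in place of the hydroxy thus leave the series without a measured number, and the limit is now shared: the limit of > 25000 nM in this assay, at which 2 of the 4 values shown sit.

As far as these compounds go, how far compound 3 and compound 4 lie past that limit remains open. So does whether an amine, a carboxylic acid or a methoxy at this place would give a value close to that of compound 2.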